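(4-methyl-1,3-thiazol-2-yl)sulfanyl in place of 4-ethylpiperazin-1-yl

A few compounds are considered here, and "the series" means these few. Any claim that something is new, unique, unknown or untested is made for them only; others in the source may bear on it.

Compound 1 `FC(F)(F)c1ccc(CSc2nc(N3CCNCC3)cc(C(F)(F)F)n2)cc1` gives 5870 nM
Compound 2 `CCN1CCN(c2cc(C(F)(F)F)nc(SCc3ccc(C(F)(F)F)cc3)n2)CC1` gives 25600 nM

Both values come from a functional assay on MGC-803 cells (Homo sapiens) for inhibition, read by MTT assay, with a stated time of 72 h (a lower number here means a stronger inhibitor, a higher number a weaker inhibitor), and compound 2 stands highest of the two. Among the measured compounds shown here, the only measured step is a 4.4-fold higher number from compound 1 to compound 2 (0.64 log units; beyond the scatter) for ethyl in place of hydrogen on an amine nitrogen in a ring. Compound 3 `Cc1csc(Sc2cc(C(F)(F)F)nc(SCc3ccc(C(F)(F)F)cc3)n2)n1` is unmeasured and loses the whole group that carries that nitrogen: (4-methyl-1,3-thiazol-2-yl)sulfanyl in place of 4-ethylpiperazin-1-yl on an aromatic carbon is the difference, with (4-methyl-1,3-thiazol-2-yl)sulfanyl in place of 4-ethylpiperazin-1-yl on an aromatic carbon. For the measured compounds named here, no measured step covers this exchange, so the earlier step serves only as a guide to size. With compound 2 at 25600 nM as the higher number, a modest move downward is expected, though the direction is uncertain. The expected change is a 2.1-fold lower number from compound 2 to compound 3 (0.33 log units; beyond the scatter) as a rough estimate. In this assay the estimated value for compound 3 is 12000 nM with a range from 3000 nM to 45000 nM as the expected span.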

Compound 3, half-maximal inhibitory concentration: 21300 nM
Estimate against measurement, compound 3: 1.8-fold (0.25 log units) below; measured number inside the range.
By their numbers in this assay, from the lowest: compound 1; then compounds 3 and 2 (each within the scatter of the next).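

In this assay, replacing the 4-ethylpiperazin-1-yl group with (4-methyl-1,3-thiazol-2-yl)sulfanyl on this aromatic carbon gives no readable difference (a 1.2-fold lower number from compound 2 to compound 3 (0.08 log units; within the scatter)), even though the entering group has a five-membered aromatic ring and a sulfur link. Compound 1, with its piperazin-1-yl group, remains apart from this new compound too (a 3.6-fold higher number from compound 1 to compound 3 (0.56 log units; beyond the scatter)), so among these three compounds only the one with the unsubstituted piperazine gives the lower number. Nothing available explains why these groups compare as they do.

The compounds shown leave open whether the lower number of compound 1 requires the piperazine ring itself or would also appear with an open-chain amine or a morpholine ring. They also do not show how a methyl or hydroxyethyl group on the piperazine nitrogen would compare with the ethyl group of compound 2.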